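Cytotoxicity notes on the amidoxime series, compound 3

The compounds below may be only part of what the source reports. "The series", "measured", "known", "first", "only" and "open" are said of these compounds alone.

Measured so far in an ADME assay on J774.A1 cells (Mus musculus) for cytotoxicity, read by MTT assay, with a stated time of 72 h; on this read-out lower numbers stand for higher toxicity in this test and higher numbers for lower toxicity in this test:
compound 1 `CC1(c2ccc(-c3ccc(/C(N)=N\O)cc3)cc2)CC(S(=O)(=O)c2ccc(F)cc2)=C(c2ccc(/C(N)=N\O)cc2)O1` gives 3940 nM;
compound 2 `CC1(c2ccc(Cl)cc2)CC(S(=O)(=O)c2ccc(F)cc2)=C(c2ccc(/C(N)=N\O)cc2)O1` gives 31500 nM.

Within the data shown here, compound 2 stands at the higher of the two numbers, with compound 1 the only neighbour at an 8.0-fold higher number from compound 1 to compound 2 (0.90 log units; beyond the scatter). Compound 3 `CC1(c2ccc(-c3cccc(/C(N)=N\O)c3)cc2)CC(S(=O)(=O)c2ccc(F)cc2)=C(c2ccc(/C(N)=N\O)cc2)O1` differs from compound 2 by a group of 10 heavy atoms (7 carbon, 2 nitrogen, 1 oxygen; one six-membered aromatic ring of carbon only) in place of one chlorine atom, on an aromatic carbon. Among the measured compounds shown here, the one measured step that bears on this change is the reverse one, an 8.0-fold higher number from compound 1 to compound 2 (0.90 log units; beyond the scatter), which was beyond the scatter. Restoring a group of the same composition in this assay is therefore expected to move the number back by a comparable amount; the estimated step is a 7.0-fold lower number from compound 2 to compound 3 (0.85 log units; beyond the scatter), downward. For compound 3 the estimate is 4500 nM (range 1500 nM to 13000 nM).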

Compound 3, half-maximal cytotoxic concentration: 11000 nM
Estimate against measurement, compound 3: 2.4-fold (0.39 log units) below, within the range that was stated.
By their numbers in this assay, from the lowest: compound 1; then compound 3; then compound 2.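

In this assay, replacing chloro with this aryl group again lowers the number, a 2.9-fold lower number from compound 2 to compound 3 (0.46 log units; beyond the scatter), so both aryl groups measured at this aromatic carbon stand below the chloro compound. Composition alone does not set the number, since two groups of identical composition still differ, a 2.8-fold higher number from compound 1 to compound 3 (0.45 log units; beyond the scatter).

From the compounds shown here alone, whether the lower numbers follow the added ring or its amidoxime stays open, and a plain phenyl, or an amine or carboxylic acid in place of the amidoxime, would separate the two. No measurement shown accounts for these shifts.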